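Benzyloxy-anilino series: antiproliferative read-out at the limit

A few compounds are considered here, and "the series" means these few. Any claim that something is new, unique, unknown or untested is made for them only; others in the source may bear on it.

Measured compounds:
compound 1 `O=[N+]([O-])c1ccc(COc2ccc(Nc3ncnc4cc5c(cc34)OCCOCCO5)cc2)cc1`, > 100000 nM
compound 2 `FC(F)(F)c1ccc(COc2ccccc2Nc2ncnc3cc4c(cc23)OCCOCCOCCO4)cc1`, > 100000 nM
compound 3 `FC(F)(F)c1ccc(COc2ccc(Nc3ncnc4cc5c(cc34)OCCOCCO5)cc2)cc1`, > 100000 nM

In a functional assay on DU-145 cells (Homo sapiens) for antiproliferative activity, read by MTT assay, with a stated time of 72 h (on this read-out lower numbers stand for stronger inhibition and higher numbers for weaker inhibition), compound 1 gives > 100000 nM, which is a limit of the assay and not a number. Compound 2 likewise stands at a limit in this assay, namely > 100000 nM. Compound 3 gives > 100000 nM, again a limit. The change from compound 3 to compound 1 is nitro in place of trifluoromethyl on an aromatic carbon; the resulting step that the two limits leave unreadable from compound 3 to compound 1 cannot be read because both values sit at the limit of > 100000 nM in this assay, at which 3 of the 3 values shown sit.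

Compound 4 `O=[N+]([O-])c1ccc(COc2ccccc2Nc2ncnc3cc4c(cc23)OCCOCCOCCO4)cc1` is not yet measured. From compound 2 it differs by nitro in place of trifluoromethyl on an aromatic carbon, the same change as that from compound 3 to compound 1. The difference between the cores of compound 2 and compound 3 is not broken down here.

For compound 4 in this assay the expected step is a step that the limit leaves unreadable from compound 2 to compound 4, which rests on a step that the two limits leave unreadable from compound 3 to compound 1 giving no readable size and on every measured value resting at a limit. Compound 4 is therefore estimated at 150000 nM, with a likely range from 50000 nM to 500000 nM, most probably reported as a limit once more.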

Compound 4, half-maximal inhibitory concentration: > 100000 nM
Compound 4 ended at the assay's limit; the forecaster's own chance of this, stated with the estimate: 85%; the middle value lies beyond the limit too.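

In this assay compound 4 gives > 100000 nM, a limit of the assay and not a number. No new step can be read from compound 2 to compound 4, because both values sit at the same limit: the limit of > 100000 nM in this assay, at which 4 of the 4 values shown sit. The compounds shown leave open what size, if any, the change from trifluoromethyl to nitro has in this assay.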